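The source may hold more compounds than are shown below. What is called first, only, known or untested is meant among the compounds shown, and "the series" means these compounds.

The measured compounds, with their values in a functional assay (spleen, spleen) for activation, with Mus musculus as the target; on this read-out higher numbers stand for an effect only at larger amounts of compound and lower numbers for an effect already at smaller amounts:

Compound 1, `Nc1ncnc2c1nc(O)n2Cc1ccc(Cl)cc1`: 10 uM
Compound 2, `CCCCCNc1nc(N)c2nc(O)n(Cc3ccccc3)c2n1`: 0.1 uM
Compound 3, `Nc1ncnc2c1nc(O)n2Cc1ccccc1`: 10 uM

Compound 3 stands level with compound 1; together the two give the highest numbers of the three, and the change between them is no change at the digits printed from compound 1 to compound 3 (within the scatter), so nothing can be read into their order. Compound 2 lies far from both: the change a 100-fold higher number from compound 2 to compound 3 (2.00 log units; beyond the scatter) is large and well beyond the scatter, and it comes from removing the pentylamino group on the shared core, not from the benzyl ring.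

Compound 4, `COc1ccccc1Cn1c(O)nc2c(N)ncnc21`, differs from compound 3 in one place: methoxy in place of hydrogen on an aromatic carbon. The new group sits on an aromatic carbon of a six-membered aromatic ring of carbon only. Going by the values given here, the one measured step that concerns that ring is no change at the digits printed from compound 1 to compound 3 (within the scatter), where swapping chloro for hydrogen left the number unchanged. The large step of a 100-fold higher number from compound 2 to compound 3 (2.00 log units; beyond the scatter) touches a different part of the molecule and does not bear on a change to this ring. Among the compounds with values here, with only one relevant comparison, and that one flat, the expectation for compound 4 is modest.

Compound 4 is therefore expected to show no change at the digits printed from compound 3 to compound 4 (within the scatter). Compound 4 is estimated at 10 uM, within a range from 3 uM to 30 uM.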

Compound 4, minimum effective concentration: 10 uM
For compound 4 middle estimate and measured number coincide at the digits printed, within the range that was stated.
By their numbers in this assay, from the lowest: compound 2; then compounds 1, 3 and 4 (each within the scatter of the next).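

In this assay, the step of no change at the digits printed from compound 3 to compound 4 (within the scatter) shows that a methoxy group on an aromatic carbon of the benzyl ring, ortho to a large group, leaves the number within the scatter. The earlier compounds had shown this only for the exchange of chloro and hydrogen, so there are now two single changes on this ring, with different groups, and neither moves the number beyond the scatter; the one large step among the compounds shown remains the one at the pentylamino group, elsewhere on the shared core. Nothing among the data shown bears on why the methoxy group leaves the number where it is.

As far as these compounds go, what remains open is whether this holds for other groups at this place on the ring, such as an amine, a carboxylic acid or a longer chain like butoxy. It is also open whether the methoxy group would be as neutral on the core that carries pentylamino, where compound 2 gives 0.1 uM, since every change to the ring shown here was read on the core without that group.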